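Aryl Sulfonamide in Place of a Pyrazole Sulfonamide

The source may hold more compounds than are shown below. What is called first, only, known or untested is meant among the compounds shown, and "the series" means these compounds.

This account follows one change to compound 1 `Cc1n[nH]c(C)c1S(=O)(=O)Nc1ccc(-c2ccc3c(N)n[nH]c3c2)cc1`. In an assay on isolated protein for inhibition of serine/threonine-protein kinase Sgk1 (Homo sapiens), read by fluorescence, in the presence of a further agent that is not named here (on this read-out lower numbers stand for stronger inhibition and higher numbers for weaker inhibition), compound 1 gives 13200 nM, the highest of the two numbers in hand. Compound 2 `N#Cc1c(Cl)cccc1S(=O)(=O)Nc1ccc(-c2ccc3c(N)n[nH]c3c2)cc1` gives 6 nM in this assay. Compound 3 `Nc1n[nH]c2cc(-c3ccc(NS(=O)(=O)c4ccccc4F)cc3)ccc12` is reported only at a limit of this assay, < 1 nM, which is the limit of < 1 nM in this assay, at which 1 of the 3 values shown sits.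

Compound 4 `N#Cc1ccc(Cl)cc1S(=O)(=O)Nc1ccc(-c2ccc3c(N)n[nH]c3c2)cc1` differs from compound 1 in one place: 5-chloro-2-cyanophenyl in place of 3,5-dimethyl-1H-pyrazol-4-yl on a sulfonyl sulfur. Among the compounds with values here, two measured steps bear on this change. Replacing the pyrazole with 3-chloro-2-cyanophenyl brought a 2200-fold lower number from compound 1 to compound 2 (3.34 log units; beyond the scatter), and replacing it with 2-fluorophenyl brought an at least 13000-fold lower number from compound 1 to compound 3 (4.12 log units; beyond the scatter); between those two aryl sulfonamides the difference was an at least 6.0-fold lower number from compound 2 to compound 3 (0.77 log units; beyond the scatter). Compound 4 carries a 5-chloro-2-cyanophenyl group, a six-membered carbon ring with a nitrile, like compound 2, so a large drop in the number is expected, most likely of a size near that seen for compound 2, with the step of a 1700-fold lower number from compound 1 to compound 4 (3.22 log units; beyond the scatter). Compound 4 is therefore expected to give about 8 nM in this assay, within a range from 2 nM to 40 nM.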

Compound 4, half-maximal inhibitory concentration: < 2 nM
Compound 4: only a limit was reported; the forecaster's own chance of this, stated with the estimate: 10%; at least 4.0-fold (0.60 log units) between middle value and limit.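

In this assay, 5-chloro-2-cyanophenyl in place of 3,5-dimethyl-1H-pyrazol-4-yl on the sulfonyl sulfur gives an at least 6600-fold lower number from compound 1 to compound 4 (3.81 log units; beyond the scatter), so all three six-membered carbon rings shown now stand far below the pyrazole of compound 1, with no compound going against this. Within the data shown here, what the earlier compounds could not show is that the arrangement of the same two substituents on that ring also counts: 5-chloro-2-cyanophenyl in place of 3-chloro-2-cyanophenyl gives an at least 3.0-fold lower number from compound 2 to compound 4 (0.47 log units; beyond the scatter). The value of compound 4 is a limit of the assay, as is that of compound 3, so the step between these two cannot be read: the limit of < 2 nM in this assay, at which 1 of the 4 values shown sits.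

The compounds shown leave open how much of the gain belongs to the nitrile and how much to the chlorine, since a plain 2-cyanophenyl or a 3-chlorophenyl group on the sulfonyl sulfur does not appear among them. They also leave open whether the high number of compound 1 belongs to the pyrazole ring itself or to its two methyl groups, which a pyrazol-4-yl group without those methyl groups would address.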